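The compounds below may be only part of what the source reports. "The series", "measured", "known", "first", "only" and "open" are said of these compounds alone.

Measured compounds:
Compound 1, `O=C(c1ccc(Cl)cc1)N1CC(c2nc(-c3cccc(F)c3)no2)C1`, 2500 nM
Compound 2, `O=C(N1CCCCC1)N1CC(c2nc(-c3cccc(Cl)c3)no2)C1`, 370 nM
Compound 3, `O=C(c1ccc(F)c(F)c1)N1CC(c2nc(-c3cccc(F)c3)no2)C1`, 3200 nM

In an assay on HEK293 cells for positive allosteric modulation of metabotropic glutamate receptor 5 (Homo sapiens), read by FLIPR (on this read-out higher numbers stand for an effect only at larger amounts of compound and lower numbers for an effect already at smaller amounts), compound 3 gives the highest of the three numbers. Its nearest neighbour is compound 1, and the step of a 1.3-fold higher number from compound 1 to compound 3 (0.11 log units; within the scatter) lies within the scatter, so these two cannot be told apart. Compound 2 stands far lower, beyond the scatter.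

Compound 4, `O=C(c1ccc(F)cc1)N1CC(c2nc(-c3cccc(F)c3)no2)C1`, has not yet been measured. It differs from compound 3 by hydrogen in place of fluoro on an aromatic carbon, that is, one fluoro group is taken off the ring that sits on the carbonyl carbon, leaving a 4-fluorophenyl group. Among the compounds with values here, the only measured step that touches this ring is a 1.3-fold higher number from compound 1 to compound 3 (0.11 log units; within the scatter), which swapped one halogenated ring for another without a change beyond the scatter. No measured step removes a single halogen from this ring, so the direction of the change is not shown by the data. The expected step of a 1.1-fold lower number from compound 3 to compound 4 (0.03 log units; within the scatter) is therefore small, with no change beyond the scatter. Compound 4 is estimated at 3000 nM in this assay, within a range from 1200 nM to 8000 nM.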

Compound 4, half-maximal effective concentration: 2400 nM
Compound 4: the middle estimate sits 1.3-fold (0.10 log units) above what was measured; low and high end bracket the measured number.
By their numbers in this assay, from the lowest: compound 2; then compounds 4, 1 and 3 (each within the scatter of the next).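

In this assay, taking one fluoro group off the 3,4-difluorophenyl ring gives a 1.3-fold lower number from compound 3 to compound 4 (0.12 log units; within the scatter) and thus no readable difference, so hydrogen and fluoro cannot be told apart at this place on the ring. Within the data shown here, compound 4 also gives the first direct comparison of two halogens on this ring: fluoro in place of chloro gives a 1.0-fold lower number from compound 1 to compound 4 (0.02 log units; within the scatter) and so is equally unreadable. Nothing available bears on the reason for these results.

From the compounds shown here alone, every aryl group on the carbonyl here carries only halogens, so it remains open whether a methoxy group, a nitrile or an amine on that ring would shift the number beyond the scatter. Compound 2 differs from the others in more than one place, which leaves its lower number unassigned to any single change.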